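This account rests on a few compounds, and the source may have more. Where it says the series, first, only, none or still open, it means among the compounds named here.

Measured so far in a functional assay on PC-3 cells (Homo sapiens) for antiproliferative activity, read by sulforhodamine B assay; on this read-out lower numbers stand for stronger inhibition and higher numbers for weaker inhibition:

- compound 1, `CCCCCCCCCCCCCCCCCCNC(=O)[C@@H]1CSC(c2cc(OC)c(OC)c(OC)c2)N1`, gives 4000 nM
- compound 2, `CCCCCCCCCCCCCCCCCCNC(=O)[C@@H]1CSC(c2ccc(N(C)C)cc2)N1`, gives 6000 nM
- compound 3, `CCCCCCCCCCCCCCCCCCNC(=O)[C@H]1NC(c2cc(OC)c(OC)c(OC)c2)SC1(C)C`, gives only a limit of the assay, > 20000 nM

Compound 1 and compound 2 share a core and differ in one place: 4-(dimethylamino)phenyl in place of 3,4,5-trimethoxyphenyl on a saturated ring carbon. That change gives a 1.5-fold higher number from compound 1 to compound 2 (0.18 log units; within the scatter), so the two values cannot be told apart on this read-out.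

Compound 3 carries a second core; how it differs from the core of compound 1 is not broken down here. For compound 3 the assay reports no number, only the limit (the limit of > 20000 nM in this assay, at which 1 of the 3 values shown sits).

Compound 4, `CCCCCCCCCCCCCCCCCCNC(=O)[C@H]1NC(c2ccc(N(C)C)cc2)SC1(C)C`, is not yet measured in this assay. It stands to compound 3 as compound 2 stands to compound 1: 4-(dimethylamino)phenyl in place of 3,4,5-trimethoxyphenyl on a saturated ring carbon. The place differs in its surroundings, since in compound 3 the saturated ring carbon is also two ring bonds from the ring atom that bears two methyl groups, so this is the same kind of change rather than the same change.

The expectation for compound 4 rests on two points: the measured step of the same kind, a 1.5-fold higher number from compound 1 to compound 2 (0.18 log units; within the scatter), was within the scatter, and compound 3 already sits at the limit of > 20000 nM in this assay, at which 1 of the 3 values shown sits. The step from compound 3 to compound 4 is therefore expected to be about a step that the limit leaves unreadable from compound 3 to compound 4, and compound 4 is estimated at 30000 nM, with a range of 15000 nM to 80000 nM, most likely again reported only as a limit.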

Compound 4, half-maximal inhibitory concentration: > 20000 nM
Compound 4: a limit, no number; the forecaster's own chance of this, stated with the estimate: 80%; the middle value is on the limit's open side.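

In this assay compound 4 gives > 20000 nM as a limit of the assay and not as a number. Within the data shown here, compound 3 sits at the same limit, so no step between compound 3 and compound 4 can be read: the limit of > 20000 nM in this assay, at which 2 of the 4 values shown sit. The compounds shown leave open how far 4-(dimethylamino)phenyl and 3,4,5-trimethoxyphenyl differ on the core of compound 3, and how far either compound lies past the limit.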